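Swapping a Chloro for a Methyl on the Acid Ring

The source may hold more compounds than are shown below. What is called first, only, known or untested is meant among the compounds shown, and "the series" means these compounds.

Compound 3 `Cc1c(OCCCCOc2ccc(C(=O)O)c(Cl)c2)ccc(C(=O)CC2CCCC2)c1O` reaches 40% in an assay on HEK293 cells for positive allosteric modulation of metabotropic glutamate receptor 3 (Rattus norvegicus), read by thallium flux, with a stated time of 2.5 min; a lower number here means a smaller maximal response, a higher number a larger maximal response. Compound 1 `Cc1c(OCCCCOCOc2ccc(C(=O)O)cc2)ccc(C(=O)CC2CCCC2)c1O` gives 46.9%, a number within the usual scatter of compound 3, while compound 2 `Cc1c(OCCCCOc2ccc(C(=O)O)cc2Cl)ccc(C(=O)CC2CCCC2)c1O` gives 27.4%, so compound 3 stands above compound 2 with a number 12.6 percentage points higher from compound 2 to compound 3 (beyond the scatter). Compound 4 `Cc1cc(OCCCCOc2ccc(C(=O)CC3CCCC3)c(O)c2C)ccc1C(=O)O` differs from compound 3 only by methyl in place of chloro on an aromatic carbon. Among the measured compounds shown here, no measured step exchanges these same two groups; the nearest guides are a number 6.9 percentage points lower from compound 1 to compound 3 (within the scatter) and a number 12.6 percentage points higher from compound 2 to compound 3 (beyond the scatter), which show that altering the group on the carboxy-bearing ring shifted the maximal response modestly or not at all. The step of no change at the digits printed from compound 3 to compound 4 (within the scatter) is therefore expected to stay within the scatter. Compound 4 is estimated at 40%, in a range from 25% to 55%.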

Compound 4, largest response reached (reported as percent of maximum), in percent of the reference or control that the assay uses: 23.7%
Compound 4: the middle estimate sits 16.3 percentage points above what was measured; measured number outside the range, below it.
By their numbers in this assay, from the lowest: compounds 4 and 2 (each within the scatter of the next); then compounds 3 and 1 (each within the scatter of the next).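

Methyl in place of chloro, ortho to a carboxy group, gives a number 16.3 percentage points lower from compound 3 to compound 4 (beyond the scatter) in this assay, so exchanging one heavy atom at this position is enough to change the maximal response. The 4-carboxy-3-methylphenyl group also gives a number 3.7 percentage points lower from compound 2 to compound 4 (within the scatter) and a number 23.2 percentage points lower from compound 1 to compound 4 (beyond the scatter), which puts it level with the 4-carboxy-2-chlorophenyl group and clearly under the (4-carboxyphenoxy)methyl group. No measurement here explains why the methyl compound differs from the chloro compound. Going by these compounds, how fluoro, methoxy or a plain hydrogen at this same position would compare remains open.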